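Ring Amine in Place of Diisopropylamino on Compound 3

This account rests on a few compounds, and the source may have more. Where it says the series, first, only, none or still open, it means among the compounds named here.

Measured compounds:
compound 1 `CCCCCCCCCCCCCC[C@H](O)[C@H](CO[Si](c1ccccc1)(c1ccccc1)C(C)(C)C)NC(=O)OC(C)(C)C`: 3.11%
compound 2 `CCCCCCCCCCCCCC[C@H](OCOC)[C@H](CO[Si](c1ccccc1)(c1ccccc1)C(C)(C)C)NC(=O)OC(C)(C)C`: -2.89%
compound 3 `CCCCCCCCCCCCCC[C@H](OCOC)[C@H](CN(C(C)C)C(C)C)NC(=O)OC(C)(C)C`: 26.6%

For the measured compounds named here, in a functional assay on NCI-H358 cells (Homo sapiens) for antiproliferative activity, read by sulforhodamine B assay, with a stated time of 48 h, tested at 10 uM (on this read-out lower numbers stand for less inhibition and higher numbers for more inhibition at the one concentration tested (going by the name of the read-out)), compound 1 gives 3.11% and compound 2 gives -2.89%; the single measured step between them, a number 6 percentage points lower from compound 1 to compound 2 (within the scatter), changes nothing beyond the scatter. Compound 3 gives 26.6% in this assay and stands highest of the three, its gaps to compound 1 and compound 2 both being beyond the scatter.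

Compound 4 `CCCCCCCCCCCCCC[C@H](OCOC)[C@H](CN1CCN(C)CC1)NC(=O)OC(C)(C)C` differs from compound 3 in one place: 4-methylpiperazin-1-yl in place of diisopropylamino on a saturated chain carbon, two bonds along the chain from an amide-type nitrogen. Going by the values given here, no measured step bears on such an exchange of one amine for another; the only step recorded, from compound 1 to compound 2, concerns an oxygen elsewhere on the chain and stayed within the scatter. With nothing to point in either direction, compound 4 is expected to sit close to compound 3, the step of a number 1.6 percentage points lower from compound 3 to compound 4 (within the scatter) being estimated as none beyond the scatter. Compound 4 is therefore estimated at 25% in this assay, in the range 5% to 50%.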

Compound 4, a percentage reported as inhibition, at one concentration (the size of the read-out at that concentration, not a potency): 18.9%
The estimate for compound 4 lay 6.1 percentage points above the measured number; the measured number falls inside the stated range.
By their numbers in this assay, from the lowest: compounds 2 and 1 (each within the scatter of the next); then compounds 4 and 3 (each within the scatter of the next).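

In this assay the exchange of diisopropylamino for 4-methylpiperazin-1-yl on a saturated chain carbon, two bonds along the chain from an amide-type nitrogen, gives a number 7.7 percentage points lower from compound 3 to compound 4 (within the scatter) and so leaves the read-out unchanged beyond the scatter. For the compounds shown here, this is the first measured change at this place, and it shows that an open-chain amine and a six-membered non-aromatic ring with a second nitrogen can be exchanged here without a step beyond the scatter, at least for this one pair. The measurements shown offer no explanation for the size of this step.

As far as these compounds go, whether morpholin-4-yl, a primary amine or a carboxylic acid at this place would give a step beyond the scatter remains open. So does whether a free hydroxyl in place of the methoxymethyl group would change the number for compound 4.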